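A few compounds are considered here, and "the series" means these few. Any claim that something is new, unique, unknown or untested is made for them only; others in the source may bear on it.

The shared core can be seen in compound 1 `Cc1noc(-c2cc3cc(F)ccc3[nH]2)n1` and compound 2 `Cc1noc(-c2cc3cc(Cl)ccc3[nH]2)n1`, which differ in a single substituent. In a functional assay on MIA PaCa-2 cells (Homo sapiens) for antiproliferative activity, read by WST assay, with a stated time of 72 h (a higher number here means a weaker inhibitor, a lower number a stronger inhibitor), compound 1 gives 19400 nM. Compound 2 gives > 50000 nM, which is a limit of this assay rather than a number, (the limit of > 50000 nM in this assay, at which 1 of the 2 values shown sits). The measured step between the two is an at least 2.5-fold higher number from compound 1 to compound 2 (0.41 log units; beyond the scatter). Compound 2 therefore stands at the weaker end of the two values shown, and without an exact number of its own. Compound 3 `Clc1ccc(-c2noc(-c3cc4cc(Cl)ccc4[nH]3)n2)cc1` arises from compound 2 by 4-chlorophenyl in place of methyl on an aromatic carbon. Among the compounds with values here, no measured step touches this position or this kind of exchange; the only measured step, an at least 2.5-fold higher number from compound 1 to compound 2 (0.41 log units; beyond the scatter), concerns a different part of the molecule and a different pair of groups, so it gives no direction for the present change. The expectation for compound 3 in this assay must therefore stay wide. Compound 3 is estimated at 30000 nM, in a range from 6000 nM to 50000 nM. This estimate means an at least 1.6-fold lower number from compound 2 to compound 3 (0.22 log units; that floor lies within the scatter), and it carries a substantial chance that the assay again reports only a limit.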

Compound 3, half-maximal inhibitory concentration: > 50000 nM
Compound 3 gave a limit, no number; the forecaster's own chance of this, stated with the estimate: 40%; middle value at least 1.6-fold (0.22 log units) away from the limit.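

Compound 2 and compound 3 both give a limit rather than a number in this assay, so no step between them can be read, and the evidence is a shared ceiling: the limit of > 50000 nM in this assay, at which 2 of the 3 values shown sit.

The compounds shown leave open whether 4-chlorophenyl in place of methyl changes the antiproliferative activity at all, and in which direction.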